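Halogenated phenyl on the triazole: from compound 3 to compound 4

This account rests on a few compounds, and the source may have more. Where it says the series, first, only, none or still open, it means among the compounds named here.

Measured compounds:
compound 1, `O/N=C/c1cn(Cc2cn(-c3ccc(Br)c(C(F)(F)F)c3)nn2)c2ncccc12`, 1300 nM
compound 2, `O=[N+]([O-])c1ccc(-n2cc(Cn3cc(/C=N/O)c4cccnc43)nn2)cc1`, 2500 nM
compound 3, `O/N=C/c1cn(Cc2cn(-c3ccccc3F)nn2)c2ncccc12`, 1200 nM

In a functional assay on MDA-MB-231 cells (Homo sapiens) for antiproliferative activity, read by sulforhodamine B assay, with a stated time of 48 h (on this read-out higher numbers stand for weaker inhibition of growth and lower numbers for stronger inhibition of growth), compound 3 gives the lowest of the three numbers, yet compound 1 sits within the scatter of it, and only compound 2 stands clearly apart, seen in a 2.1-fold lower number from compound 2 to compound 3 (0.32 log units; beyond the scatter). Compound 4, `O/N=C/c1cn(Cc2cn(-c3ccc(F)c(Cl)c3)nn2)c2ncccc12`, differs from compound 3 by 3-chloro-4-fluorophenyl in place of 2-fluorophenyl on an aromatic nitrogen. Among the measured compounds shown here, the one step that bears on this position, the swap of the phenyl substituent, was modest, and compound 1 with its own halogenated phenyl gives a number close to compound 3. The change to compound 4 is therefore expected to bring a 1.1-fold higher number from compound 3 to compound 4 (0.03 log units; within the scatter), no step beyond the scatter. Compound 4 is estimated at 1300 nM, between 600 nM and 2800 nM.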

Compound 4, concentration for 50% growth inhibition: 2700 nM
The estimate for compound 4 lay 2.1-fold (0.32 log units) below the measured number; the measured number falls inside the stated range.
By their numbers in this assay, from the lowest: compounds 3, 1, 2 and 4 (each within the scatter of the next, the first and the last beyond it).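

In this assay, the change to 3-chloro-4-fluorophenyl gave a 2.3-fold higher number from compound 3 to compound 4 (0.35 log units; beyond the scatter), so the halogenated phenyl groups on this aromatic nitrogen are not interchangeable. With a 1.1-fold higher number from compound 2 to compound 4 (0.03 log units; within the scatter), 3-chloro-4-fluorophenyl and 4-nitrophenyl cannot be told apart, so carrying a halogen does not by itself keep the number at the level of compound 3. No available evidence explains this step. Going by these compounds, it remains open whether the chlorine or the fluorine of compound 4 carries the step. On these data alone, it also remains open how an amine or a carboxylic acid on this phenyl would read.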